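Swapping Methyl for Methoxy on the Carbonyl Carbon

The source may hold more compounds than are shown below. What is called first, only, known or untested is meant among the compounds shown, and "the series" means these compounds.

Measured so far:
compound 1 `CC(=O)NCC#CCn1cncc1C`: 66 mg/kg
compound 2 `CC(=O)N(C)CC#CCN1CCCC1`: 0.55 mg/kg
compound 3 `COC(=O)NCC#CCn1cncc1C`: > 100 mg/kg

In a functional assay on the whole organism for agonist activity, with Mus musculus as the target (on this read-out lower numbers stand for an effect already at smaller amounts and higher numbers for an effect only at larger amounts of compound), compound 1 gives 66 mg/kg. Compound 3 reaches only > 100 mg/kg, which is a limit of the measurement rather than a number, as noted in the limit of > 100 mg/kg in this assay, at which 1 of the 3 values shown sits. Compound 2 gives 0.55 mg/kg, the lowest of the two numbers. How the core of compound 2 differs from the core of compound 1 is not broken down here.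

The change from compound 1 to compound 3 is methoxy in place of methyl on a carbonyl carbon and it produced an at least 1.5-fold higher number from compound 1 to compound 3 (0.18 log units; that floor lies within the scatter). Compound 4 `COC(=O)N(C)CC#CCN1CCCC1` has not yet been measured; it carries the same change relative to compound 2, namely (methoxy in place of methyl on a carbonyl carbon), at a place described in the same words for both pairs.

The earlier step is known only as a floor, so the expected step from compound 2 to compound 4 is set a little larger than that floor, which is uncertain. Compound 4 is therefore expected at 1.5 mg/kg, within a range from 0.5 mg/kg to 6 mg/kg. The step this expectation means is a 2.7-fold higher number from compound 2 to compound 4 (0.44 log units; beyond the scatter).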

Compound 4, dose for half-maximal effect: 3 mg/kg
Beside the measured number, compound 4's estimate is 2.0-fold (0.30 log units) below it; low and high end bracket the measured number.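

In this assay, methoxy in place of methyl on a carbonyl carbon gives a 5.5-fold higher number from compound 2 to compound 4 (0.74 log units; beyond the scatter), so on this core the change means that a larger dose is needed for the same effect. On the other core, compound 3 gives > 100 mg/kg, which is a limit and not a number. The two results therefore do not show that the change carries over from one core to the other with the same size, and on the core of compound 1 even the direction is not settled, so only the result on the core of compound 2 is firm: the same change on two cores in this assay, an at least 1.5-fold higher number (0.18 log units; that floor lies within the scatter) from compound 1 to compound 3 and a 5.5-fold higher number (0.74 log units; beyond the scatter) from compound 2 to compound 4; the limit leaves it open whether they differ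

The compounds shown leave open how other groups would behave on the same carbonyl carbon, for example an ethyl group or an amine. On these data alone, compound 1 and compound 2 also differ in more than one place, so it remains open which of those differences makes the two cores respond as they do.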